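Methoxy to amino-acid swap on a double-bonded ring carbon

The compounds below may be only part of what the source reports. "The series", "measured", "known", "first", "only" and "open" are said of these compounds alone.

Measured so far, in an ADME assay on KB cells (Homo sapiens) for cytotoxicity, with a stated time of 48 h; a lower number here means a stronger inhibitor, a higher number a weaker inhibitor:
compound 1 `C=C1[C@H](C)CCC[C@]1(C)CC/C(C)=C/CC1=C(O)C(=O)C=C(OC)C1=O`: > 10 ug/mL
compound 2 `COC1=CC(=O)C(O)=C(C/C=C(\C)CC[C@@]2(C)CCC=C(C)[C@H]2C)C1=O`: > 10 ug/mL
compound 3 `C=C1[C@H](C)CCC[C@]1(C)CC/C(C)=C/CC1=C(O)C(=O)C=C(N[C@H](C(=O)O)[C@H](C)O)C1=O`: > 10 ug/mL

Each of these values is a limit of the assay, not a number. Compound 2 therefore has only a limit in this assay, and the two other values shown are limits as well. For the measured compounds named here, the one step available, a step that the two limits leave unreadable from compound 1 to compound 3, is unreadable, since (the limit of > 10 ug/mL in this assay, at which 3 of the 3 values shown sit).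

Compound 4 `CC1=CCC[C@](C)(CC/C(C)=C/CC2=C(O)C(=O)C=C(N[C@@H](C(=O)O)[C@H](C)O)C2=O)[C@@H]1C` differs from compound 2 as follows: (1-carboxy-2-hydroxypropyl)amino in place of methoxy on a double-bonded ring carbon. Going by the values given here, the only comparable step, from compound 1 to compound 3, gives no size, so no direction can be read. For compound 4 the expected step is estimated as a step that the limit leaves unreadable from compound 2 to compound 4, a step that is expected to stay within the scatter at most. Compound 4 is expected at 15 ug/mL in this assay, within 5 ug/mL to 50 ug/mL, most likely again reported as a limit.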

Compound 4, half-maximal inhibitory concentration: > 10 ug/mL
Compound 4: no number, only a limit (the forecaster's own chance of this, stated with the estimate: 75%); the middle value does not contradict the limit.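

Compound 2 and compound 4 both give only a limit, not a number, so no step can be read between them: the limit of > 10 ug/mL in this assay, at which 4 of the 4 values shown sit.

Left open in this assay is whether (1-carboxy-2-hydroxypropyl)amino in place of methoxy makes any difference, in either direction.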